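The compounds below may be only part of what the source reports. "The series", "measured", "known", "first", "only" and "open" are said of these compounds alone.

Compound 2 `CCOC(=O)C1=C(C)N/C(=C/c2cc(C)n(-c3ccc(N(C)C)cc3)c2C)C1=O` gives 3.4 in a physicochemical assay for lipophilicity, read by HPLC, at pH 7.4 (a higher number here means a more lipophilic compound, a lower number a more polar compound), and is the more polar of the two compounds that have a number there. In this assay, for the measured compounds named here, compound 1 `CCOC(=O)C1=C(C)N/C(=C/c2cc(C)n(-c3ccc(CN(C)C)cc3)c2C)C1=O` gives 8.3, so compound 2 stands lowest of the two, with compound 1 as its only measured neighbour. Compound 3 `CCOC(=O)C1=C(C)N/C(=C/c2cc(C)n(-c3cccc(O)c3)c2C)C1=O` belongs to the same series, but in this assay compound 3 has "not determined" (no result reported), so no number is reported for it.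

The step to compound 4 `CCOC(=O)C1=C(C)N/C(=C/c2cc(C)n(-c3ccc(CN4CCCCC4)cc3)c2C)C1=O` consists of (piperidin-1-yl)methyl in place of dimethylamino on an aromatic carbon. Going by the values given here, only one measured step bears on this change: a number 4.90 log units lower from compound 1 to compound 2 (beyond the scatter), the move from a methylene-linked amine to an amine attached directly to the aromatic ring. The change from compound 2 to compound 4 runs the other way, restoring a methylene-linked amine, and the (piperidin-1-yl)methyl group carries more carbon than the (dimethylamino)methyl group of compound 1. Among the compounds with values here, compound 4 is therefore expected to move a large step upward in this assay, at least as large as the one seen between compound 1 and compound 2, that is a number 5.40 log units higher from compound 2 to compound 4 (beyond the scatter). For compound 4 the estimated value in this assay is 8.8, with a range from 7.5 to 10.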

Compound 4, distribution coefficient: 8.5
For compound 4 the middle estimate is 0.30 log units above the measured one; low and high end bracket the measured number.
By their numbers in this assay, from the lowest: compound 2; then compounds 1 and 4 (each within the scatter of the next).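

In this assay the exchange of dimethylamino for (piperidin-1-yl)methyl on the aromatic carbon para to a large group gives a number 5.10 log units higher from compound 2 to compound 4 (beyond the scatter) as a second large step at this position, and the first seen going upward. Exchanging only the amine on the saturated chain carbon, piperidin-1-yl in place of dimethylamino, gives a number 0.20 log units higher from compound 1 to compound 4 (within the scatter) and so no readable change, even though a six-membered non-aromatic ring enters. Across these three compounds, then, the large gap follows the presence of the chain carbon between the aromatic ring and the amine and not the kind of amine, with compound 1 and compound 4 lying together and compound 2 standing apart.

As far as these compounds go, it stays open whether a longer chain between the aromatic ring and the amine, a morpholine in place of the piperidine, or a carboxylic acid at this position would fall with compound 1 and compound 4 or with compound 2. Nothing among the data shown gives a reason for the size of this gap.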